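Swapping a methyl for trifluoromethyl on the aryl ring

The compounds below may be only part of what the source reports. "The series", "measured", "known", "first", "only" and "open" are said of these compounds alone.

Of the compounds shown here, three have been measured, all built on one shared core. Compound 1 `Cc1cccc(NC(=O)N[C@H](C)c2ccccc2)c1` and compound 2 `Cc1cccc(NC(=O)N[C@@H](C)c2ccccc2)c1` have the same atoms and bonds and differ only in how one saturated chain carbon is drawn. In an ADME assay on the whole organism with Oryza sativa as the target, tested at 0.1 uM (a lower number here means a stronger effect, a higher number a weaker effect of the compound at the concentration tested), compound 1 gives 100%, while compound 2 gives 99%, so the change a number 1 percentage points lower from compound 1 to compound 2 (within the scatter) lies within the scatter, which fits (the fact that compounds 1 and 2 differ only in the configuration as drawn). Compound 3 `CC(C)c1ccccc1NC(=O)N[C@@H](C)c1ccccc1` gives 99%. Compound 2 therefore stands level with compound 3 at the digits shown, the pair forming the lowest of the three numbers, and all three values sit within the scatter of one another.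

Compound 4 `C[C@H](NC(=O)Nc1cccc(C(F)(F)F)c1)c1ccccc1` is the next candidate. Compared with compound 2 it shows this single difference: trifluoromethyl in place of methyl on an aromatic carbon. For the measured compounds named here, no measured step bears on this exchange; the only step available concerns configuration alone and was within the scatter. The change from compound 2 to compound 4 is therefore expected to be a number 3 percentage points lower from compound 2 to compound 4 (within the scatter), with no direction beyond the scatter. Compound 4 is expected to give about 96%, in a range from 78% to 100%.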

Compound 4, a percentage reported as activity, at one concentration (the size of the read-out at that concentration, not a potency): 94%
Compound 4: the middle estimate sits 2 percentage points above what was measured, and the stated range covers the measured number.
By their numbers in this assay, from the lowest: compounds 4, 2, 3 and 1 (each within the scatter of the next).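

Putting trifluoromethyl in place of methyl on this aromatic carbon, which takes the group from one heavy atom to four, gives in this assay a number 5 percentage points lower from compound 2 to compound 4 (within the scatter). For the compounds shown here, the only earlier step concerned configuration alone, so this is the first reading of a change to the group itself at this position. It shows that this larger group can sit here without moving the number beyond the scatter at the concentration tested, so no effect of the exchange can be claimed. Nothing known so far bears on this exchange.

From the compounds shown here alone, whether a different kind of group on this aromatic carbon, such as an amine or a carboxylic acid, would move the number beyond the scatter stays open. So does whether trifluoromethyl reads the same with the saturated chain carbon drawn the other way.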